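Aryl sulfone variation on the shared core: single-point binding

This account rests on a few compounds, and the source may have more. Where it says the series, first, only, none or still open, it means among the compounds named here.

compound 1 `CC1CCN(c2c(S(=O)(=O)c3ccc(F)c(Cl)c3)cnc3cc(Cl)ccc23)CC1` 94%
compound 2 `CC1CCN(c2c(S(=O)(=O)c3cccc(Cl)c3)cnc3cc(Cl)ccc23)CC1` 92%
compound 3 `CC1CCN(c2c(S(=O)(=O)c3cccc(C#N)c3)cnc3cc(Cl)ccc23)CC1` 94%

The three measured compounds share one core and differ only in the aryl group on the sulfonyl sulfur. In an assay on isolated protein for displacement of a labelled ligand from metabotropic glutamate receptor 5 (Homo sapiens), with a stated time of 60 min, tested at 1 uM (on this read-out higher numbers stand for more inhibition at the one concentration tested (going by the name of the read-out) and lower numbers for less inhibition), compound 1 gives 94%, compound 2 gives 92% and compound 3 gives 94%. Compound 3 stands level with compound 1, the two together the highest of the three numbers; the step of a number 2 percentage points higher from compound 2 to compound 3 (within the scatter), the step of no change at the digits printed from compound 1 to compound 3 (within the scatter) and the step of a number 2 percentage points lower from compound 1 to compound 2 (within the scatter) are all within the scatter, so the three aryl groups tried so far cannot be told apart in this assay.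

Compound 4 `CC1CCN(c2c(S(=O)(=O)c3ccc(F)cc3)cnc3cc(Cl)ccc23)CC1` is not yet measured. It differs from compound 3 by 4-fluorophenyl in place of 3-cyanophenyl on a sulfonyl sulfur. Among the measured compounds shown here, the steps that bear on this are no change at the digits printed from compound 1 to compound 3 (within the scatter), which exchanged the whole aryl group, and a number 2 percentage points lower from compound 1 to compound 2 (within the scatter), which removed a fluoro from an aromatic carbon; neither moved the number beyond the scatter. Compound 4 keeps a fluoro on its aryl ring, as compound 1 does, and drops the cyano that compound 3 carries, an exchange of the same kind as those already seen without effect. Compound 4 is therefore expected to stay near the level of compound 3, with a number 3 percentage points lower from compound 3 to compound 4 (within the scatter) as the estimated step. The estimate for compound 4 is 91%, between 80% and 97%.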

Compound 4, a percentage reported as inhibition, at one concentration (the size of the read-out at that concentration, not a potency): 91%
Estimate against measurement, compound 4: no gap at the digits printed, and the stated range covers the measured number.
By their numbers in this assay, from the lowest: compounds 4, 2, 1 and 3 (each within the scatter of the next).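

In this assay, among the compounds shown here, the sulfonyl sulfur position also holds its number with 4-fluorophenyl, with a number 3 percentage points lower from compound 3 to compound 4 (within the scatter) and a number 1 percentage points lower from compound 2 to compound 4 (within the scatter), so neither exchange of the aryl group separates compound 4 from the earlier compounds. Compounds 1, 2 and 3 each carry a chloro or a cyano on the aryl ring and compound 4 carries neither, yet removing the chloro gives a number 3 percentage points lower from compound 1 to compound 4 (within the scatter), so at this one concentration the number does not depend on that chloro. Nothing available explains why these four aryl groups read alike.

A single concentration leaves open whether compounds 1, 2, 3 and 4 would separate in a full concentration-response measurement, since all their steps lie within the scatter. Also open, as far as these compounds go, is whether the number would hold with a carboxylic acid or a primary amine on the aryl ring, or with a saturated cyclohexyl in place of the aryl group on the sulfonyl sulfur.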